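Aryl hydrazone variation on a shared urea core

A few compounds are considered here, and "the series" means these few. Any claim that something is new, unique, unknown or untested is made for them only; others in the source may bear on it.

Measured so far:
compound 1 `CN(C)CCn1cnnc1-c1cc(Oc2ccc(NC(=O)N/N=C/c3ccc(O)c(O)c3)cc2F)ccn1`; in a functional assay on A549 cells (Homo sapiens) for cytotoxicity, read by MTT assay, with a stated time of 72 h (a higher number here means a weaker inhibitor, a lower number a stronger inhibitor), compound 1 gives > 100000 nM, which is a limit of the assay and not a number.
compound 2 `CN(C)CCn1cnnc1-c1cc(Oc2ccc(NC(=O)N/N=C/c3cc(Br)c(O)c(Br)c3)cc2F)ccn1`; in this assay compound 2 gives > 100000 nM, again a limit and not a number.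
compound 3 `COc1ccc(/C=N/NC(=O)Nc2ccc(Oc3ccnc(-c4nncn4CCN(C)C)c3)c(F)c2)c(OC)c1`; in this assay compound 3 gives 2820 nM.

Compound 3 thus stands alone as the only numerical result in the series; the two other values sit at the limit (the limit of > 100000 nM in this assay, at which 2 of the 3 values shown sit). The step of an at least 35-fold lower number from compound 1 to compound 3 (1.54 log units; beyond the scatter) and the step of an at least 35-fold lower number from compound 2 to compound 3 (1.54 log units; beyond the scatter) are both large, whereas the step that the two limits leave unreadable from compound 1 to compound 2 cannot be read.

Compound 4 `COc1cc(/C=N/NC(=O)Nc2ccc(Oc3ccnc(-c4nncn4CCN(C)C)c3)c(F)c2)cc(OC)c1OC` differs from compound 3 in one place: 3,4,5-trimethoxyphenyl in place of 2,4-dimethoxyphenyl on a carbon with a double bond to nitrogen.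

Neither measured step concerns this change. Going by the values given here, both large steps replace a hydroxy-bearing ring with a methoxy-bearing one; here a methoxy-bearing ring is exchanged for another methoxy-bearing ring, so no measured step gives a direction. The step of a 1.2-fold higher number from compound 3 to compound 4 (0.09 log units; within the scatter) is therefore expected to stay within the scatter, with some risk of weakening. Compound 4 is estimated at 3500 nM, in the range 1000 nM to 15000 nM.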

Compound 4, half-maximal inhibitory concentration: > 100000 nM
Compound 4: a limit, no number (the forecaster's own chance of this, stated with the estimate: 15%); middle value at least 28-fold (1.45 log units) from the limit.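

In this assay, exchanging one methoxy-bearing ring for another at this position is not a neutral change: 3,4,5-trimethoxyphenyl in place of 2,4-dimethoxyphenyl gives an at least 35-fold higher number from compound 3 to compound 4 (1.54 log units; beyond the scatter). The earlier steps shown here left open whether methoxy groups on this ring were enough for a measurable value, and this step shows that they are not, since the number depends on which methoxy-bearing ring is present. The value of compound 4, > 100000 nM, is a limit of the assay and not a number, and the series now reads as follows: the limit of > 100000 nM in this assay, at which 3 of the 4 values shown sit.

Going by these compounds, the steps among compound 1, compound 2 and compound 4 cannot be read, so the order of these three remains unknown. On these data alone, it remains open whether a 4-methoxyphenyl, a 2-methoxyphenyl or a 2,4-dichlorophenyl ring on this carbon would give a number in this assay.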